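The source may report more compounds than this note shows. Statements on the series, on what has been measured and on what is new or still open speak of the compounds shown alone.

In a functional assay (trachea) with Cavia porcellus as the target (on this read-out lower numbers stand for stronger inhibition and higher numbers for weaker inhibition), compound 1 `Cn1nc(-c2cccnc2)c2ccccc2c1=O` gives 11500 nM and compound 2 `O=c1c2ccccc2c(-c2cccnc2)nn1CCSc1ccccc1` gives 9120 nM. Compound 2 holds the lower of the two numbers, but the step of a 1.3-fold lower number from compound 1 to compound 2 (0.10 log units; within the scatter) is within the scatter, so the pair reads as level. Compound 3 `CC(C)NC(=O)CCCn1nc(-c2cccnc2)c2ccccc2c1=O` carries the change ((isopropylcarbamoyl)methyl in place of phenylsulfanyl on a saturated chain carbon, two bonds along the chain from an aromatic nitrogen). Among the compounds with values here, the only measured step at the saturated chain carbon bound to the aromatic nitrogen is a 1.3-fold lower number from compound 1 to compound 2 (0.10 log units; within the scatter), itself within the scatter; nothing measured covers the entering group. The expected step is therefore a 1.0-fold higher number from compound 2 to compound 3 (0.02 log units; within the scatter), none beyond the scatter. Compound 3 is estimated at 9500 nM, range 3000 nM to 30000 nM.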

Compound 3, half-maximal inhibitory concentration: 64600 nM
The estimate for compound 3 lay 6.8-fold (0.83 log units) below the measured number; measured number outside the range, above it.
By their numbers in this assay, from the lowest: compounds 2 and 1 (each within the scatter of the next); then compound 3.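

In this assay, within the data shown here, this position proves sensitive to what it carries: a 7.1-fold higher number from compound 2 to compound 3 (0.85 log units; beyond the scatter) is the first step here beyond the scatter, which the earlier pair did not reach. With 2-(isopropylcarbamoyl)ethyl in place of hydrogen on the saturated chain carbon bound to the aromatic nitrogen, a 5.6-fold higher number from compound 1 to compound 3 (0.75 log units; beyond the scatter) also points to weaker inhibition, whereas (phenylsulfanyl)methyl there stayed within the scatter. No available data bear on the reason for this loss.

Open, from the compounds shown here alone, is whether the loss follows the amide or the absence of the phenylsulfanyl ring. A phenyl ring without sulfur, a carboxylic acid or a primary amine on this chain could separate the two.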